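Ester variation on a glycoside core: propargyl for catechol ethyl

The source may report more compounds than this note shows. Statements on the series, on what has been measured and on what is new or still open speak of the compounds shown alone.

Two compounds of this series have numbers in a functional assay on SK-BR-3 cells (Homo sapiens) for antiproliferative activity, read by MTT assay, with a stated time of 72 h; a higher number here means a weaker inhibitor, a lower number a stronger inhibitor. Compound 1 `C/C=C1/[C@H](O[C@@H]2O[C@H](COC(C)=O)[C@@H](OC(C)=O)[C@H](OC(C)=O)[C@H]2OC(C)=O)OC=C(C(=O)OC)[C@H]1CC(=O)OCCC` gives 6600 nM, and compound 2 `C/C=C1/[C@H](O[C@@H]2O[C@H](CO)[C@@H](O)[C@H](O)[C@H]2O)OC=C(C(=O)OC)[C@H]1CC(=O)OCCc1ccc(O)c(O)c1` gives 160000 nM. Compound 2 thus stands at the higher of the two numbers, and the gap to compound 1 is well beyond the usual scatter; since the two differ in more than one place, the values alone are taken as they stand, without attributing the gap to any single change.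

Compound 3 `C#CCOC(=O)C[C@@H]1C(C(=O)OC)=CO[C@@H](O[C@@H]2O[C@H](CO)[C@@H](O)[C@H](O)[C@H]2O)/C1=C/C` is not yet measured. Relative to compound 2 the change is ethynyl in place of 3,4-dihydroxybenzyl on a saturated chain carbon bound to an oxygen next to a carbonyl group.

Among the compounds with values here, no single-change step between measured compounds is available to calibrate this. Within the data shown here, compound 1, the only compound carrying a short ester chain, gives 6600 nM, and on that basis a lower number than compound 2 is expected for compound 3, with the step from a 3.2-fold lower number from compound 2 to compound 3 (0.51 log units; beyond the scatter) estimated to lie beyond the scatter. Compound 3 is estimated at 50000 nM, in a range of 12000 nM to 200000 nM.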

Compound 3, half-maximal inhibitory concentration: > 15000 nM
Compound 3: a limit, no number; the forecaster's own chance of this, stated with the estimate: 20%; the middle value is on the limit's open side.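

In this assay, within the data shown here, compound 3 gives > 15000 nM, a limit of the assay and not a number, so no step from compound 2 to compound 3 can be read. The compounds shown leave open what ethynyl in place of 3,4-dihydroxybenzyl does on its own.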